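Meta Substituent Swap on an Anilino Pyrimidine Series

The source may report more compounds than this note shows. Statements on the series, on what has been measured and on what is new or still open speak of the compounds shown alone.

Compound 1 `CC(C)c1ccc(-c2nc(SCc3cn(CC(=O)NC(=O)Nc4ccccn4)nn3)nc(Nc3ccccc3Cl)c2C#N)cc1`: 6790 nM
Compound 2 `CC(C)c1ccc(-c2nc(SCc3cn(CC(=O)NC(=O)Nc4ccccn4)nn3)nc(Nc3cccc(Cl)c3)c2C#N)cc1`: 1130 nM

In a functional assay on B16-F10 cells (Mus musculus) for inhibition, read by MTT assay, with a stated time of 72 h (on this read-out lower numbers stand for stronger inhibition and higher numbers for weaker inhibition), compound 1 gives 6790 nM and compound 2 gives 1130 nM. Among the measured compounds shown here, the one measured step, a 6.0-fold lower number from compound 1 to compound 2 (0.78 log units; beyond the scatter), separates the two. Compound 2 therefore stands at the lowest of the two numbers, with compound 1 above it by that step.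

Compound 3 `CC(C)c1ccc(-c2nc(SCc3cn(CC(=O)NC(=O)Nc4ccccn4)nn3)nc(Nc3cccc(C(F)(F)F)c3)c2C#N)cc1` has not yet been measured. It differs from compound 2 by trifluoromethyl in place of chloro on an aromatic carbon. For the measured compounds named here, no measured step bears directly on this exchange; the only step known, a 6.0-fold lower number from compound 1 to compound 2 (0.78 log units; beyond the scatter), concerns the position of chloro, not its replacement. The expectation for compound 3 rests on compound 2 alone, so the number is estimated to sit close to that of compound 2, within the scatter, as a 1.1-fold lower number from compound 2 to compound 3 (0.05 log units; within the scatter). Compound 3 is thus expected to give about 1000 nM in this assay, between 350 nM and 3000 nM.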

Compound 3, half-maximal inhibitory concentration: 1700 nM
Estimate against measurement, compound 3: 1.7-fold (0.23 log units) below; the measured number falls inside the stated range.
By their numbers in this assay, from the lowest: compounds 2 and 3 (each within the scatter of the next); then compound 1.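

In this assay, trifluoromethyl in place of chloro on this aromatic carbon, 4 heavy atoms for 1, gives a 1.5-fold higher number from compound 2 to compound 3 (0.18 log units; within the scatter), so this position accepts either group without a change beyond the scatter. Replacing the 2-chlorophenyl with 3-(trifluoromethyl)phenyl gives a 4.0-fold lower number from compound 1 to compound 3 (0.60 log units; beyond the scatter), which shows that among these three compounds the lower numbers go with a substituent meta to a large group, now with two different groups and no compound against it. Nothing shown here speaks to the cause of these results.

The compounds shown leave open whether a group of another kind at this position, such as an amine or a carboxylic acid, would read the same. They also leave open how trifluoromethyl would read at the place chloro holds in compound 1.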